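The source may report more compounds than this note shows. Statements on the series, on what has been measured and on what is new or still open speak of the compounds shown alone.

Measured series in a functional assay on DLD-1 cells (Homo sapiens) for cytotoxicity, with a stated time of 48 h; on this read-out lower numbers stand for stronger inhibition and higher numbers for weaker inhibition:
compound 1 `Cc1ccc2oc(/C=C/[S+](C)[O-])cc(=O)c2c1` gives 7000 nM
compound 2 `C[S+]([O-])/C=C/c1cc(=O)c2ccccc2o1` gives 8000 nM
compound 3 `CC(C)COc1ccc2oc(/C=C/[S+](C)[O-])cc(=O)c2c1` gives 5000 nM

Among the compounds with values here, of the three numbers, the one for compound 3 is the lowest, but its separation from the rest is small: a 1.4-fold lower number from compound 1 to compound 3 (0.15 log units; within the scatter) and a 1.6-fold lower number from compound 2 to compound 3 (0.20 log units; within the scatter). Within the data shown here, no compound can be called the most active. The aromatic substituent has varied across methyl, hydrogen and isobutoxy without any step beyond the scatter, a 1.1-fold higher number from compound 1 to compound 2 (0.06 log units; within the scatter) included.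

Compound 4 `COc1ccc2oc(/C=C/[S+](C)[O-])cc(=O)c2c1` differs from compound 3 by hydrogen in place of isopropyl on a saturated chain carbon bound to an oxygen on an aromatic ring. The change shortens the chain on the aromatic oxygen rather than removing it. Among the measured compounds shown here, the steps that bear on it are the three at the same aromatic position, all within the scatter. Nothing in the series suggests that the size or presence of a group at this position moves the read-out: compound 2 with hydrogen and compound 3 with isobutoxy both sit within the scatter of compound 1. The step of a 1.2-fold higher number from compound 3 to compound 4 (0.08 log units; within the scatter) is therefore expected to remain within the scatter. Compound 4 is estimated at 6000 nM, with a range of 3000 nM to 13000 nM.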

Compound 4, half-maximal inhibitory concentration: 5700 nM
The estimate for compound 4 lay 1.1-fold (0.02 log units) above the measured number; measured number inside the range.
By their numbers in this assay, from the lowest: compounds 3, 4, 1 and 2 (each within the scatter of the next).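

In this assay the change from isobutoxy to methoxy gives a 1.1-fold higher number from compound 3 to compound 4 (0.06 log units; within the scatter) and so, for this one shortening of the chain on the aromatic oxygen, does not separate the two ethers. Methoxy also cannot be told apart from the groups that lack this oxygen, with a 1.4-fold lower number from compound 2 to compound 4 (0.15 log units; within the scatter) against hydrogen and a 1.2-fold lower number from compound 1 to compound 4 (0.09 log units; within the scatter) against methyl in the same read-out, which leaves all four compounds undistinguished at this aromatic position. No supporting data offer an explanation for this flat result. 

Still open, going by these compounds, is whether a different kind of group at this position, such as an amine, a carboxylic acid or a chain longer than isobutoxy, would give a step beyond the scatter. On these data alone, how the read-out responds to changes elsewhere on the shared core also remains open.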